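Four related compounds tested for colon cancer cell growth inhibition

The source may hold more compounds than are shown below. What is called first, only, known or untested is meant among the compounds shown, and "the series" means these compounds.

Of the compounds shown here, three have been measured in a functional assay on HCT-116 cells (Homo sapiens) for antiproliferative activity, read by CCK-8 assay, with a stated time of 72 h, tested at 2 uM (on this read-out higher numbers stand for a stronger effect at the one concentration tested and lower numbers for a weaker effect), and a fourth awaits measurement. Compound 2 `Nc1ccccc1NC(=O)/C=C/c1ccc(Cn2cnc3c(Nc4cccc(OC(F)(F)F)c4)nc(Cl)nc32)cc1` gives 2.8% in this assay. Compound 1 `CC1CCN(c2nc(Cl)nc3c2ncn3Cc2ccc(/C=C/C(=O)Nc3ccccc3N)cc2)CC1` differs from compound 2 in one group: 4-methylpiperidin-1-yl in place of (3-(trifluoromethoxy)phenyl)amino on an aromatic carbon. The step of a number 1.4 percentage points higher from compound 2 to compound 1 (within the scatter). Compound 3 `Nc1ccccc1NC(=O)c1ccc(Cn2cnc3c(Nc4cccc(OC(F)(F)F)c4)nc(Cl)nc32)cc1` differs from compound 2 elsewhere: (2-aminophenyl)carbamoyl in place of 2-((2-aminophenyl)carbamoyl)ethenyl on an aromatic carbon. In this assay compound 3 gives 1.6%, and the step of a number 1.2 percentage points lower from compound 2 to compound 3 (within the scatter). Compound 1 gives 4.24% in this assay.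

Compound 4 `CC1CCN(c2nc(Cl)nc3c2ncn3Cc2ccc(C(=O)Nc3ccccc3N)cc2)CC1` has not yet been measured. It stands to compound 3 as compound 1 stands to compound 2: 4-methylpiperidin-1-yl in place of (3-(trifluoromethoxy)phenyl)amino on an aromatic carbon. The two descriptions of the place agree word for word, so this is the same change made a second time, on the core of compound 3 rather than that of compound 2. Because the earlier instance a number 1.4 percentage points higher from compound 2 to compound 1 (within the scatter) stayed within the scatter, the step from compound 3 to compound 4 is expected to be small as well, a number 1.4 percentage points higher from compound 3 to compound 4 (within the scatter). Compound 4 is therefore expected to give about 3% in this assay, with a plausible range from -5% to 12%.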

Compound 4, a percentage reported as inhibition, at one concentration (the size of the read-out at that concentration, not a potency): 70.9%
Compound 4: middle estimate off by 67.9 percentage points, on the low side; measured number above the stated range.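

In this assay, the change to 4-methylpiperidin-1-yl from (3-(trifluoromethoxy)phenyl)amino did not carry over from one core to the other, giving a number 69.3 percentage points higher from compound 3 to compound 4 (beyond the scatter), which differs from the earlier step: the same change on two cores in this assay, a number 1.4 percentage points higher (within the scatter) from compound 2 to compound 1 and a number 69.3 percentage points higher (beyond the scatter) from compound 3 to compound 4, 67.9 percentage points apart, beyond the scatter of two such steps. The change to (2-aminophenyl)carbamoyl from 2-((2-aminophenyl)carbamoyl)ethenyl likewise depends on its core, giving a number 66.7 percentage points higher from compound 1 to compound 4 (beyond the scatter): the same change on two cores in this assay, a number 1.2 percentage points lower (within the scatter) from compound 2 to compound 3 and a number 66.7 percentage points higher (beyond the scatter) from compound 1 to compound 4, 67.9 percentage points apart, beyond the scatter of two such steps. The two changes are thus not independent among these compounds, since the large steps appear only on reaching compound 4, which carries both groups, but this does not show why they combine in this way or whether the same would hold for any other pair of groups in the series.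

Going by these compounds, it remains open whether a morpholin-4-yl or an unsubstituted piperidin-1-yl group in place of the 4-methylpiperidin-1-yl would keep the effect seen with compound 4. On these data alone, it is also open whether a saturated two-carbon chain in place of the ethenyl link would behave like compound 1 or like compound 4.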